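Sulfonyl to sulfanyl exchange in a small growth-inhibition series

This account rests on a few compounds, and the source may have more. Where it says the series, first, only, none or still open, it means among the compounds named here.

Of the compounds shown here, three have so far been measured in a functional assay on DU-145 cells (Homo sapiens) for inhibition, read by trypan blue exclusion, with a stated time of 96 h; a lower number here means a stronger inhibitor of growth, a higher number a weaker inhibitor of growth. Compound 1 `O=C(/C(=C\c1ccc(Cl)c([N+](=O)[O-])c1)S(=O)(=O)c1ccc(Br)cc1)c1ccc(Br)cc1` gives 10000 nM in this assay. Compound 2 `O=C(/C(=C\c1c(O)cc(O)cc1O)Sc1ccc(Br)cc1)c1ccc(Cl)cc1` gives 50000 nM in this assay. Compound 3 `O=C(/C(=C\c1c(O)cc(O)cc1O)S(=O)(=O)c1ccc(Br)cc1)c1ccc(Cl)cc1` reaches only a limit of this assay, > 100000 nM, which is the limit of > 100000 nM in this assay, at which 1 of the 3 values shown sits. The structural change (4-bromophenyl)sulfanyl in place of (4-bromophenyl)sulfonyl on a double-bonded chain carbon bound to a carbonyl carbon and a double-bonded chain carbon made an at least 2.0-fold lower number from compound 3 to compound 2 (0.30 log units; that floor lies within the scatter). How the core of compound 1 differs from the core of compound 3 is not broken down here; in this assay compound 1 sits lowest of the two numbers recorded, with compound 2 nearest to it.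

Compound 4 `O=C(/C(=C\c1ccc(Cl)c([N+](=O)[O-])c1)Sc1ccc(Br)cc1)c1ccc(Br)cc1` is not yet measured in this assay. For the measured compounds named here, it differs from compound 1 in (4-bromophenyl)sulfanyl in place of (4-bromophenyl)sulfonyl on a double-bonded chain carbon bound to a carbonyl carbon and a double-bonded chain carbon, the same kind of change as the one from compound 3 to compound 2, at a place described in the same words. The earlier step started from a limit, so only its floor is known. The writer expects compound 4 to show a 2.0-fold lower number from compound 1 to compound 4 (0.30 log units; within the scatter), resting on an at least 2.0-fold lower number from compound 3 to compound 2 (0.30 log units; that floor lies within the scatter) and on the number for compound 1, 10000 nM. The estimate for compound 4 in this assay is 5000 nM, expected to lie between 2000 nM and 15000 nM.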

Compound 4, concentration for 50% growth inhibition: 10000 nM
Beside the measured number, compound 4's estimate is 2.0-fold (0.30 log units) below it; low and high end bracket the measured number.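

In this assay, putting (4-bromophenyl)sulfanyl in place of (4-bromophenyl)sulfonyl on the core of compound 1 gave no change at the digits printed from compound 1 to compound 4 (within the scatter). Set beside the earlier step, the exchange reads as follows: the same change on two cores in this assay, an at least 2.0-fold lower number (0.30 log units; that floor lies within the scatter) from compound 3 to compound 2 and no change at the digits printed (within the scatter) from compound 1 to compound 4; the limit leaves it open whether they differ. The data therefore do not show that the two cores respond alike to this exchange, nor that they respond differently, and an effect on the core of compound 3 that fails to appear on the core of compound 1 is neither shown nor ruled out, with the earlier step resting on this: the limit of > 100000 nM in this assay, at which 1 of the 4 values shown sits.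

The compounds shown leave open how this exchange behaves on any core other than these two, since only two pairs carry it. They also leave open whether a (4-bromophenyl)sulfinyl group, or an amine, a carboxylic acid or a longer alkyl chain in place of the (4-bromophenyl)sulfanyl group, would move the number for growth inhibition on either core.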